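Working notes: methyl in place of 1-hydroxyethyl

This account rests on a few compounds, and the source may have more. Where it says the series, first, only, none or still open, it means among the compounds named here.

Two compounds of the series carry numbers in a physicochemical assay for lipophilicity, at pH 7.4; on this read-out higher numbers stand for higher lipophilicity and lower numbers for lower lipophilicity. Compound 1 `CNC(=O)c1cc(C(=O)NC2CCC2)cn(Cc2ccncc2)c1=O` gives 1.7. Compound 2 `CNC(=O)c1cc(C(=O)NC2CC2)cn(Cc2cccc([C@@H](C)O)c2)c1=O` gives 2.2. Compound 2 therefore stands highest of the two, and its gap to the nearest, compound 1, lies beyond the scatter of repeated measurements. Among the measured compounds shown here, no two measured compounds differ in a single place, so no measured step is available to lean on.

Compound 3 `CNC(=O)c1cc(C(=O)NC2CC2)cn(Cc2cccc(C)c2)c1=O` has not yet been measured in this assay. It differs from compound 2 in one place: methyl in place of 1-hydroxyethyl on an aromatic carbon. The site is an aromatic carbon of a six-membered aromatic ring of carbon only, meta to a large group. For the measured compounds named here, nothing among the measured compounds isolates this kind of change, so the expectation rests on the counted difference alone: the group that leaves carries 1 hydrogen-bond donor and 1 hydrogen-bond acceptor, the methyl that enters carries 0 of each.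

For compound 3 the expected step is a number 0.70 log units higher from compound 2 to compound 3 (beyond the scatter), upward and beyond the scatter. Compound 3 is estimated at 2.9, with a range from 2.4 to 3.4.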

Compound 3, distribution coefficient: 3.6
Compound 3: the middle estimate sits 0.70 log units below what was measured; the whole stated range lies below it.
By their numbers in this assay, from the lowest: compound 1; then compound 2; then compound 3.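

In this assay, among the compounds shown here, methyl in place of 1-hydroxyethyl on an aromatic carbon, meta to a large group, gives a number 1.40 log units higher from compound 2 to compound 3 (beyond the scatter), the first measured step to isolate a single change. This position is therefore not indifferent to the read-out, since exchanging this one group with the rest of the structure held constant produces a large step, which compound 1, differing from compound 2 in more than one place, could not show. No measurement shown here accounts for the size of this step.

The change removes heavy atoms, a hydrogen-bond donor, a hydrogen-bond acceptor and a defined stereocentre together, so the pair of compounds cannot assign the step to any one of these differences. Going by these compounds, an ethyl group or a hydroxymethyl group on the same aromatic carbon would separate the carbon chain from the hydroxyl, while the size of the same exchange on another scaffold of the series, such as one carrying the cyclobutyl amide of compound 1, remains open.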